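Methylcarbamoyl to dimethylcarbamoyl: working notes on the series

The source may hold more compounds than are shown below. What is called first, only, known or untested is meant among the compounds shown, and "the series" means these compounds.

Measured in a functional assay on Ishikawa cells (Homo sapiens) for antiproliferative activity, read by CCK-8 assay, with a stated time of 48 h (a higher number here means a weaker inhibitor, a lower number a stronger inhibitor), so far
compound 1 `C=C(C)C(=O)NCCOc1ccc(Oc2c(-c3ccc(F)cc3)sc3cc(O)ccc23)cc1` gives > 25000 nM as a limit
compound 2 `CNC(=O)/C=C/CNCCOc1ccc(Oc2c(-c3ccc(F)cc3)sc3cc(O)ccc23)cc1` gives 15500 nM as a number

Among the compounds with values here, compound 2 with 15500 nM holds the only actual number so far. Compound 1 with > 25000 nM is reported only as a limit. Compound 3 `CN(C)C(=O)/C=C/CNCCOc1ccc(Oc2c(-c3ccc(F)cc3)sc3cc(O)ccc23)cc1` carries methyl in place of hydrogen on an amide-type nitrogen in comparison with compound 2: methyl in place of hydrogen on an amide-type nitrogen, so that methylcarbamoyl becomes dimethylcarbamoyl. Within the data shown here, the sole measured step an at least 1.6-fold lower number from compound 1 to compound 2 (0.20 log units; that floor lies within the scatter) is a different change on an amine nitrogen and rests on the limit of > 25000 nM in this assay, at which 1 of the 2 values shown sits, so it gives no size for this one. Among the measured compounds shown here, no measured step touches the amide-type nitrogen. The expectation therefore rests on compound 2 with 15500 nM and no shift beyond the scatter is expected in this assay for this change. The expected step of a 1.1-fold lower number from compound 2 to compound 3 (0.04 log units; within the scatter) stays within the scatter. For compound 3 the estimated value is 14000 nM with an expected range from 6500 nM to 25000 nM for this half-maximal inhibitory concentration.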

Compound 3, half-maximal inhibitory concentration: 11900 nM
Beside the measured number, compound 3's estimate is 1.2-fold (0.07 log units) above it; measured number inside the range.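

In this assay, within the data shown here, this is the first reading on the amide-type nitrogen, and methyl in place of hydrogen there gives a step that stays within the scatter (a 1.3-fold lower number from compound 2 to compound 3 (0.11 log units; within the scatter)), so the amide hydrogen can be replaced by methyl without a shift that can be told from repeat variation. Among these compounds, the comparison with the (1-methylethenyl)carbonyl compound now passes the scatter for the first time (an at least 2.1-fold lower number from compound 1 to compound 3 (0.32 log units; beyond the scatter)), although the 3-(dimethylcarbamoyl)prop-2-en-1-yl group and the 3-(methylcarbamoyl)prop-2-en-1-yl group cannot be told apart by their values in this assay. Compound 1 is held only as a limit (> 25000 nM), so that step gives a floor and no true size: the limit of > 25000 nM in this assay, at which 1 of the 3 values shown sits.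

The compounds shown leave open whether a bigger replacement on the amide-type nitrogen, such as ethyl, a longer chain or a pyrrolidine ring closed over that nitrogen, would move the number beyond the scatter. Also open, from the compounds shown here alone, is whether the dimethylcarbamoyl group could give way to a carboxylic acid or a methyl ester with the same outcome, since every value so far sits at a high level in this assay and none tests the carbonyl itself.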